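The compounds below may be only part of what the source reports. "The series", "measured", "known", "first", "only" and "open" are said of these compounds alone.

Measured in a functional assay (aorta) with Oryctolagus cuniculus as the target; a lower number here means tighter binding, a higher number weaker binding:
- Compound 1 `COc1cc(C(C)=O)ccc1OCCCN1CCC(C(c2ccc(F)cc2)c2ccc(F)cc2)CC1`: 1.59 nM
- Compound 2 `COc1cc(OCCCN2CCC(C(c3ccc(F)cc3)c3ccc(F)cc3)CC2)ccc1C(C)=O`: 3.16 nM

For the measured compounds named here, compound 2 stands level with compound 1 within the usual scatter, the only measured step being a 2.0-fold higher number from compound 1 to compound 2 (0.30 log units; within the scatter). Compound 3 `N#Cc1ccc(OCCCN2CCC(C(c3ccc(F)cc3)c3ccc(F)cc3)CC2)cc1` has 4-cyanophenyl in place of 4-acetyl-3-methoxyphenyl on an oxygen on a saturated carbon. That single step only exchanges 4-acetyl-2-methoxyphenyl for 4-acetyl-3-methoxyphenyl, so it offers weak guidance for this larger replacement. A modest move to a higher number in this assay is expected, with wide uncertainty: a 1.9-fold higher number from compound 2 to compound 3 (0.28 log units; within the scatter). For compound 3 the estimated value is 6 nM, with an expected range from 1.5 nM to 25 nM.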

Compound 3, dissociation constant: 5.01 nM
For compound 3 the middle estimate is 1.2-fold (0.08 log units) above the measured one; low and high end bracket the measured number.
By their numbers in this assay, from the lowest: compounds 1, 2 and 3 (each within the scatter of the next, the first and the last beyond it).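

In this assay, 4-cyanophenyl on the oxygen replaces the larger 4-acetyl-3-methoxyphenyl without leaving the scatter (a 1.6-fold higher number from compound 2 to compound 3 (0.20 log units; within the scatter)), so compound 3 stands level with compound 2 although it carries neither the acetyl nor the methoxy group. Set against 4-acetyl-2-methoxyphenyl, the same group gives the first step here to pass the scatter, and a modest one (a 3.2-fold higher number from compound 1 to compound 3 (0.50 log units; beyond the scatter)). Nothing available here bears on the reason for either step. Open, from the compounds shown here alone, is whether a plain phenyl or a 4-acetylphenyl on this oxygen would stay in the same range, and whether a carboxylic acid in place of the nitrile would.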